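A few compounds are considered here, and "the series" means these few. Any claim that something is new, unique, unknown or untested is made for them only; others in the source may bear on it.

Compound 2 `COc1cc(-c2nnc(SCC(=O)c3ccc(F)c(F)c3)n2N)cc(OC)c1OC` is known in a functional assay on HeLa cells (Homo sapiens) for antiproliferative activity, read by MTT assay, with a stated time of 48 h (a lower number here means a stronger inhibitor, a higher number a weaker inhibitor), only as a limit, > 100000 nM. Compound 1 `COc1cc(-c2nnc(SCC(=O)c3ccc(C)cc3)n2N)cc(OC)c1OC` gives 2940 nM in this assay. Among the measured compounds shown here, the single measured step, an at least 34-fold higher number from compound 1 to compound 2 (1.53 log units; beyond the scatter), ends at a limit (the limit of > 100000 nM in this assay, at which 1 of the 2 values shown sits), so its true size is a minimum. Compound 3 `COc1cc(-c2nnc(SCC(=O)Nc3ccccc3)n2N)cc(OC)c1OC` differs from compound 2 by anilino in place of 3,4-difluorophenyl on a carbonyl carbon. For the measured compounds named here, no measured step covers this ketone-to-amide change; the only step, also on the carbonyl carbon, was large, so a wide range is kept. Compound 3 is expected near 20000 nM (range 3000 nM to 100000 nM), an expected step of an at least 5.0-fold lower number from compound 2 to compound 3 (0.69 log units; beyond the scatter), with a fair chance of again only a limit.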

Compound 3, half-maximal inhibitory concentration: 8280 nM
Estimate against measurement, compound 3: 2.4-fold (0.38 log units) above; the range from low to high includes it.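

With anilino on the carbonyl carbon, the amide compound 3 stays measurable in this assay, and the collapse seen with 3,4-difluorophenyl does not carry over to this change: a 2.8-fold higher number from compound 1 to compound 3 (0.45 log units; beyond the scatter) is only a modest step. Against the difluorinated ketone, anilino gives an at least 12-fold lower number from compound 2 to compound 3 (1.08 log units; beyond the scatter). This size is a minimum, as compound 2 is only a limit: the limit of > 100000 nM in this assay, at which 1 of the 3 values shown sits.

Still open, on these data alone, is whether 3,4-difluoroanilino would repeat the large step seen among the ketones. Also open, as far as these compounds go, is how a saturated amine such as morpholine, placed on the same carbonyl carbon, would compare with anilino.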